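Formyl in place of propoxy: working notes on compound 3

The source may report more compounds than this note shows. Statements on the series, on what has been measured and on what is new or still open speak of the compounds shown alone.

Measured in an ADME assay on HepG2 cells (Homo sapiens) for cytotoxicity, read by MTT assay, with a stated time of 24 h; on this read-out higher numbers stand for lower toxicity in this test and lower numbers for higher toxicity in this test:
- Compound 1 `CC1Cn2c(nc([N+](=O)[O-])c2-c2ccccc2)O1`: > 500000 nM (a limit)
- Compound 2 `CCCOc1ccc(-c2c([N+](=O)[O-])nc3n2CC(C)O3)cc1`: > 62500 nM (a limit)

Compound 2 stands at > 62500 nM, which is a limit and not a number. Compound 1 gives > 500000 nM, which is also a limit. Within the data shown here, the series therefore holds no exact value so far.

Compound 3 `CC1Cn2c(nc([N+](=O)[O-])c2-c2ccc(C=O)cc2)O1` carries formyl in place of propoxy on an aromatic carbon of a six-membered aromatic ring of carbon only, para to a large group: formyl in place of propoxy on an aromatic carbon.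

Among the measured compounds shown here, the one measured step that bears on this change is a step that the two limits leave unreadable from compound 1 to compound 2, with propoxy in place of hydrogen on an aromatic carbon. It offers no size to carry over to the new change. The nearest reference is compound 2 at > 62500 nM, so compound 3 is expected to read high in this assay, and another limit is quite possible. The expected change is a step that the limit leaves unreadable from compound 2 to compound 3, read against a limit and therefore only loosely. For compound 3 the estimated value is 200000 nM, with an expected range of 50000 nM to 500000 nM.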

Compound 3, half-maximal cytotoxic concentration: > 51000 nM
Compound 3: only a limit was reported (the forecaster's own chance of this, stated with the estimate: 60%); the middle value lies beyond the limit too.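

Among these compounds, compound 1, compound 2 and compound 3 all stand as limits in this assay, and no step among them can be read. The compounds shown leave open whether formyl, propoxy or hydrogen on the aromatic carbon changes the half-maximal cytotoxic concentration at all, and where any exact value for the series lies.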